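Trimethoxyphenyl in place of nitrophenyl on compound 2

This account rests on a few compounds, and the source may have more. Where it says the series, first, only, none or still open, it means among the compounds named here.

Compound 1: `COc1ccc(C2CC(c3ccc(OCc4cn(Cc5ccc([N+](=O)[O-])cc5)nn4)cc3)=NN2C(C)=O)cc1`, in a functional assay on A549 cells (Homo sapiens) for inhibition, read by sulforhodamine B assay, tested at 10 uM (on this read-out higher numbers stand for more inhibition of growth at the one concentration tested and lower numbers for less inhibition of growth), compound 1 gives 26%.
Compound 2: `COc1cc(C2CC(c3ccc([N+](=O)[O-])cc3)=NN2C(C)=O)ccc1OCc1cn(Cc2ccc([N+](=O)[O-])cc2)nn1`, in this assay compound 2 gives 39%.
Compound 3: `COc1cc(C2CC(c3ccccc3)=NN2C(C)=O)ccc1OCc1cn(Cc2ccc([N+](=O)[O-])cc2)nn1`, in this assay compound 3 gives 0%.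

Compound 2 stands highest of the three in this assay; compound 1 lies lower by a margin beyond the scatter, and compound 3 lies lowest. Going by the values given here, the one measured step that touches the position of interest is a number 39 percentage points lower from compound 2 to compound 3 (beyond the scatter), a large loss when the nitro group is removed and only hydrogen remains.

Compound 4, `COc1cc(C2CC(c3cc(OC)c(OC)c(OC)c3)=NN2C(C)=O)ccc1OCc1cn(Cc2ccc([N+](=O)[O-])cc2)nn1`, differs from compound 2 in one place: 3,4,5-trimethoxyphenyl in place of 4-nitrophenyl on a carbon with a double bond to nitrogen. Among the compounds with values here, no measured step covers this particular exchange. The step from compound 2 to compound 3 shows that this position responds strongly to what is attached there, but it says nothing about a trimethoxyphenyl group, which is neither a nitro group nor a bare hydrogen. The outcome is therefore uncertain, and a downward step of moderate size, a number 19 percentage points lower from compound 2 to compound 4 (beyond the scatter), is expected, with a wide margin on either side. Compound 4 is estimated at 20% in this assay, within a range from 0% to 50%.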

Compound 4, percent growth inhibition at one concentration: 68%
Beside the measured number, compound 4's estimate is 48 percentage points below it; measured number outside the range, above it.
By their numbers in this assay, from the lowest: compound 3; then compound 1; then compound 2; then compound 4.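

In this assay, the place on the carbon with a double bond to nitrogen turns out to hold more than the 4-nitrophenyl group, since 3,4,5-trimethoxyphenyl in place of 4-nitrophenyl gives a number 29 percentage points higher from compound 2 to compound 4 (beyond the scatter), and the same group in place of plain phenyl gives a number 68 percentage points higher from compound 3 to compound 4 (beyond the scatter). The earlier step showed only a loss when the nitro group was taken away, which left open whether the number here depended on that group; compound 4 carries no nitro group on this ring and still stands above compound 2, so among these compounds the nitro group at this place is not required for growth inhibition. Nothing in the data at hand accounts for the rise seen with the three methoxy groups.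

The compounds shown leave open whether all three methoxy groups are needed, or whether a simple 4-methoxyphenyl group would give a similar number, and whether an amine or a carboxylic acid on this ring would hold the gain or lose it. They also leave open how compound 4 behaves at any concentration other than the one tested.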